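Chloro to methyl on the acyl chain of compound 2

A few compounds are considered here, and "the series" means these few. Any claim that something is new, unique, unknown or untested is made for them only; others in the source may bear on it.

Two members of the series carry numbers in a functional assay on MGC-803 cells (Homo sapiens) for cytotoxicity, read by MTT assay, with a stated time of 48 h; on this read-out higher numbers stand for weaker inhibition and lower numbers for stronger inhibition. Compound 1 `CC1=NN(C(=O)/C=C/c2ccccc2)C(c2ccccc2O)C1` gives 39600 nM in this assay. Compound 2 `CC1=NN(C(=O)CCl)C(c2cc(Br)ccc2O)C1` gives 13500 nM in this assay, the lower of the two numbers, with compound 1 standing a gap beyond the scatter above it. For the measured compounds named here, no pair of measured compounds differs in one place, so no single change has a measured step attached to it.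

Compound 3 `CCC(=O)N1N=C(C)CC1c1cc(Br)ccc1O` is not yet measured in this assay. It differs from compound 2 by one exchange: methyl in place of chloro on a saturated chain carbon bound to a carbonyl carbon. With no measured step for a change of this kind, the expectation rests on the two numbers shown. The step in this assay is expected to go toward a higher number, of a size beyond the scatter, as a 2.4-fold higher number from compound 2 to compound 3 (0.37 log units; beyond the scatter). Compound 3 is expected to give about 32000 nM in this assay, within a range from 11000 nM to 95000 nM.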

Compound 3, half-maximal inhibitory concentration: 50300 nM
Beside the measured number, compound 3's estimate is 1.6-fold (0.20 log units) below it, and the stated range covers the measured number.
By their numbers in this assay, from the lowest: compound 2; then compounds 1 and 3 (each within the scatter of the next).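

In this assay, for the compounds shown here, methyl in place of chloro on a saturated chain carbon bound to a carbonyl carbon gives a 3.7-fold higher number from compound 2 to compound 3 (0.57 log units; beyond the scatter) and is the first single change with a measured step. This position is therefore not silent: with the rest of the structure unchanged, the chloromethyl group goes with the stronger inhibition and the ethyl group with the weaker. Nothing available accounts for the direction or size of this step.

On these data alone, whether fluoro, a hydroxyl group, an amine or a longer chain on this carbon would match compound 2 or move further from it remains open. Also open, as far as these compounds go, is whether the same exchange gives a step of similar direction and size with other groups on the rest of the molecule.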